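A few compounds are considered here, and "the series" means these few. Any claim that something is new, unique, unknown or untested is made for them only; others in the source may bear on it.

For the measured compounds named here, compound 1 `O=c1oc(-c2ccccc2I)nc2ccccc12` is the only member of the series with a number in an assay on isolated protein for inhibition of complement C1r subcomponent (Homo sapiens); a higher number here means a weaker inhibitor, a lower number a stronger inhibitor: compound 1 gives 16700 nM. Compound 2 `COc1ccccc1-c1nc2ccccc2c(=O)o1` reaches only a limit in this assay, > 62500 nM, not a number. Compound 2 therefore sits at the limit of > 62500 nM in this assay, at which 1 of the 2 values shown sits, and the step of an at least 3.7-fold higher number from compound 1 to compound 2 (0.57 log units; beyond the scatter) is known only as a floor. Compound 3 `O=c1oc(-c2ccccc2I)nc2cc(Cl)ccc12` differs from compound 1 by chloro in place of hydrogen on an aromatic carbon. Going by the values given here, no measured step touches that position; the one measured step concerns the iodo group, so it gives no guide. For compound 3 the expectation is no step beyond the scatter, a 1.1-fold lower number from compound 1 to compound 3 (0.05 log units; within the scatter), with an estimated 15000 nM (range 5000 nM to 45000 nM).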

Compound 3, half-maximal inhibitory concentration: > 62500 nM
Compound 3: no number, only a limit; the forecaster's own chance of this, stated with the estimate: 15%; middle value at least 4.1-fold (0.61 log units) from the limit.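

A substituent on this carbon of the fused aromatic ring is not neutral in this assay: chloro in place of hydrogen gives an at least 3.7-fold higher number from compound 1 to compound 3 (0.57 log units; beyond the scatter). The change on the shared core therefore counts as well as the iodo group on the other ring. Compound 3 reaches only a limit, so this step is a floor and its true size is unknown: the limit of > 62500 nM in this assay, at which 2 of the 3 values shown sit.

Going by these compounds, whether the loss is specific to chloro remains open; fluoro or an amine on this carbon would test that. Chloro on the other carbons of this ring also remains open.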